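The source may hold more compounds than are shown below. What is called first, only, known or untested is meant among the compounds shown, and "the series" means these compounds.

Three compounds have been measured in an assay on isolated protein for displacement of a labelled ligand from D(4) dopamine receptor (Homo sapiens); a higher number here means a weaker inhibitor, a lower number a stronger inhibitor:

compound 1, `O=C(NC1CCN(Cc2cccc(C(F)(F)F)c2)CC1)c1cccc2ccccc12`, gives 119 nM;
compound 2, `O=C(NC1CCN(Cc2cccc(Cl)c2)CC1)c1ccc2ccccc2c1`, gives 54 nM;
compound 3, `O=C(NC1CCN(Cc2ccc(Cl)cc2)CC1)c1ccc2ccccc2c1`, gives 37 nM.

Compound 3 has the lowest of the three numbers. Its nearest neighbour is compound 2, and the step of a 1.5-fold lower number from compound 2 to compound 3 (0.16 log units; within the scatter) lies within the scatter, so the two cannot be ranked against each other. For the measured compounds named here, compound 1 sits further away, and its value compared with that of compound 3 shows a gap beyond the scatter; the two differ in more than one place, so no single step is drawn between them.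

Compound 4, `O=C(NC1CCN(Cc2cccc(Br)c2)CC1)c1ccc2ccccc2c1`, has not yet been measured. It differs from compound 3 by 3-bromophenyl in place of 4-chlorophenyl on a saturated chain carbon bound to an amine nitrogen in a ring. Going by the values given here, the only measured step that touches the same part of the molecule is the move from one chlorine position to the other, a 1.5-fold lower number from compound 2 to compound 3 (0.16 log units; within the scatter), which stayed within the scatter. Nothing measured here speaks to bromine in place of chlorine. On this basis the expectation for compound 4 is a step of a 1.4-fold higher number from compound 3 to compound 4 (0.13 log units; within the scatter), that is, no change beyond the scatter. Compound 4 is therefore estimated at 50 nM, with a range from 20 nM to 130 nM.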

Compound 4, inhibition constant: 36 nM
The estimate for compound 4 lay 1.4-fold (0.14 log units) above the measured number, within the range that was stated.
By their numbers in this assay, from the lowest: compounds 4, 3 and 2 (each within the scatter of the next); then compound 1.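

In this assay, for the compounds shown here, bromo in place of chloro on an aromatic carbon gives a 1.5-fold lower number from compound 2 to compound 4 (0.18 log units; within the scatter), the first look at the halogen itself, and this swap cannot be told apart from the ordinary spread of repeated measurements. Changing both the halogen and its ring position, as in 4-chlorophenyl to 3-bromophenyl, gives a 1.0-fold lower number from compound 3 to compound 4 (0.01 log units; within the scatter), which is also within the scatter, so compound 2, compound 3 and compound 4 cannot be ranked against one another and these three halogen patterns look interchangeable in this assay. No further data are available to explain why the number holds steady.

As far as these compounds go, it remains open whether 4-bromophenyl, or a group of a different kind at this place such as a methoxy, a nitrile or an amine, would keep the number in the same range or move it beyond the scatter. Compound 1, at 119 nM, carries trifluoromethyl and also differs from the others on the amide side, so its value cannot be assigned to either difference alone.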